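The source may hold more compounds than are shown below. What is called first, only, known or untested is meant among the compounds shown, and "the series" means these compounds.

Measured so far: compound 1 `COc1cc2ncnc(Nc3cc(F)ccc3Br)c2c(OC)c1OC` with 34.7%; compound 2 `COc1cc2ncnc(Nc3ccc(C(F)(F)F)cc3)c2c(OC)c1OC` with 29%.

In a functional assay on PC-3 cells (Homo sapiens) for inhibition, read by MTT assay, with a stated time of 72 h, tested at 10 uM (on this read-out lower numbers stand for less inhibition of growth and higher numbers for more inhibition of growth at the one concentration tested), compound 2 gives 29%, the smaller of the two numbers shown, and compound 1 gives 34.7%, a gap that lies within the scatter. Compound 3 `COc1cc2ncnc(Nc3ccc(F)cc3)c2c(OC)c1OC` has not been measured yet. It differs from compound 2 in one place: fluoro in place of trifluoromethyl on an aromatic carbon. Among the measured compounds shown here, no step between measured compounds is available to guide the expectation. A small step, downward or none beyond the scatter, is expected, estimated as a number 4 percentage points lower from compound 2 to compound 3 (within the scatter). Compound 3 is therefore expected to give about 25%, in the range 10% to 40%.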

Compound 3, percent growth inhibition at one concentration: 9.1%
Compound 3: the middle estimate sits 15.9 percentage points above what was measured; the measured number lies below the stated range.
By their numbers in this assay, from the lowest: compound 3; then compounds 2 and 1 (each within the scatter of the next).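

In this assay, the aromatic carbon para to a large group proves sensitive: fluoro in place of trifluoromethyl gives a number 19.9 percentage points lower from compound 2 to compound 3 (beyond the scatter), a change the earlier pair could not show. Setting 4-fluorophenyl in place of 2-bromo-5-fluorophenyl on the nitrogen gives a number 25.6 percentage points lower from compound 1 to compound 3 (beyond the scatter), so both substituted rings hold more growth inhibition than the 4-fluorophenyl ring of compound 3. No measurement shown here accounts for either step.

As far as these compounds go, whether a methoxy group, a chloro group or an amine on that carbon would sit nearer compound 2 or compound 3 remains open.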